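Amide side-chain variation: notes ahead of compound 4

The source may report more compounds than this note shows. Statements on the series, on what has been measured and on what is new or still open speak of the compounds shown alone.

Compound 1 `C=CC1=C(C(=O)O)C(c2ccc(F)cc2)OC1`: in a functional assay on HeLa cells (Homo sapiens) for cytotoxicity, read by MTT assay, with a stated time of 24 h (on this read-out lower numbers stand for stronger inhibition and higher numbers for weaker inhibition), compound 1 gives 67400 nM.
Compound 2 `C=CC1=C(C(=O)NCc2ccc(Cl)cc2)C(c2ccc(F)cc2)OC1`: compound 2 reaches only the limit > 100000 nM in this assay.
Compound 3 `C=CC1=C(C(=O)NCc2ccccc2F)C(c2ccc(F)cc2)OC1`: compound 3 likewise stops at the limit > 100000 nM in this assay.

Compound 3 therefore stands at the top of the measured range, with no number of its own. It shares that position with compound 2, both sitting at the limit of > 100000 nM in this assay, at which 2 of the 3 values shown sit, and only compound 1, the free acid, returns a numeric value in this assay. The one step between two amides, a step that the two limits leave unreadable from compound 2 to compound 3, is consequently unreadable, so the amide substituent has not yet been shown to move the read-out in either direction.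

Compound 4 `C=CC1=C(C(=O)NCC(C)C)C(c2ccc(F)cc2)OC1` differs from compound 3 by isopropyl in place of 2-fluorophenyl on a saturated chain carbon bound to an amide-type nitrogen. Among the compounds with values here, no measured step bears on this change in a readable way, and nothing among the measured compounds shows an amide reaching below the limit. Compound 4 is therefore expected to remain weak, with the step that the limit leaves unreadable from compound 3 to compound 4 most likely not readable at all. The estimate for compound 4 in this assay is 150000 nM, within a range of 50000 nM to 500000 nM, with a limit result expected as the more probable outcome.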

Compound 4, half-maximal inhibitory concentration: > 100000 nM
Compound 4 ended at the assay's limit; the forecaster's own chance of this, stated with the estimate: 70%; the middle value does not contradict the limit.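

Compound 4 shows that an amide side chain with no ring, isobutyl in place of 2-fluorobenzyl, also ends at a limit in this assay, so the aromatic ring of the earlier amides is not needed for that outcome: the limit of > 100000 nM in this assay, at which 3 of the 4 values shown sit.

The steps among the three amides cannot be read, and the side-chain series therefore still gives no ranking of these groups.

Compound 4 does supply the first readable step from the free acid to an amide, with isobutylamino in place of hydroxy on a carbonyl carbon, and this is an at least 1.4-fold higher number from compound 1 to compound 4 (0.17 log units; that floor lies within the scatter) and so does not by itself set the amide apart from the acid.

Still open, going by these compounds, is whether any amide can give a number rather than a limit in this read-out, for instance one whose side chain ends in a primary amine or a hydroxyl group, or one with a longer chain. Also open, on these data alone, is whether a methyl ester on the same carbonyl carbon would behave like the free acid of compound 1 or like the amides.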